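Pyridin-3-yl in place of 3,4,5-trifluorophenyl

The source may report more compounds than this note shows. Statements on the series, on what has been measured and on what is new or still open speak of the compounds shown alone.

In a functional assay on A-375 cells (Homo sapiens) for activation, with a stated time of 3 days (on this read-out higher numbers stand for an effect only at larger amounts of compound and lower numbers for an effect already at smaller amounts), compound 1 (`O=C(Nc1ccc(-c2cscn2)cc1)C1CCCN(Cc2ccc(F)c(F)c2)C1`) gives 1240 nM and compound 3 (`O=C(Nc1ccc(-c2cscn2)cc1)C1CCCN(Cc2cc(F)c(F)c(F)c2)C1`) gives 1260 nM, two values within the scatter of each other. Compound 2 (`O=C(Nc1ccc(-c2cscn2)cc1)C1CCCN(C(=O)c2ccc(F)c(F)c2)C1`) reports only a limit, > 20000 nM. Compound 4 (`O=C(Nc1ccc(-c2cscn2)cc1)C1CCCN(Cc2cccnc2)C1`) carries pyridin-3-yl in place of 3,4,5-trifluorophenyl on a saturated chain carbon bound to an amine nitrogen in a ring. Among the measured compounds shown here, two measured steps bear on this change. Adding fluoro gave a 1.0-fold higher number from compound 1 to compound 3 (0.01 log units; within the scatter), whereas the carbonyl swap gave an at least 16-fold higher number from compound 1 to compound 2 (1.20 log units; beyond the scatter), so this end of the molecule can matter, though neither step replaces the aromatic ring itself. A moderate rise is expected, a 3.2-fold higher number from compound 3 to compound 4 (0.50 log units; beyond the scatter). For compound 4 the estimated value is 4000 nM, with an expected range of 1300 nM to 15000 nM.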

Compound 4, half-maximal effective concentration: > 20000 nM
Compound 4 was reported as a limit (the forecaster's own chance of this, stated with the estimate: 15%); middle value at least 5.0-fold (0.69 log units) away from the limit.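

In this assay, replacing the aromatic ring on the saturated chain carbon bound to an amine nitrogen in a ring has a large effect: pyridin-3-yl in place of 3,4,5-trifluorophenyl gives an at least 15-fold higher number from compound 3 to compound 4 (1.20 log units; beyond the scatter), and pyridin-3-yl in place of 3,4-difluorophenyl gives an at least 16-fold higher number from compound 1 to compound 4 (1.20 log units; beyond the scatter). Thus this position tolerates an added fluoro within the scatter, but not this ring exchange. The step between compound 2 and compound 4 cannot be read, since both values are the same limit: the limit of > 20000 nM in this assay, at which 2 of the 4 values shown sit.

The compounds shown do not separate the effect of the ring nitrogen from that of losing the fluoro groups. A plain phenyl ring or a fluoro-bearing pyridin-3-yl would address this.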